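This account rests on a few compounds, and the source may have more. Where it says the series, first, only, none or still open, it means among the compounds named here.

Compound 2 `CCCn1c(SCc2cc([N+](=O)[O-])ccc2OC)nc2cc(NC(=O)NC(C)(C)C)cc(C(=O)N(C)C)c21` stands with the higher of the two numbers in an assay on isolated protein for inhibition of Gonadotropin-releasing hormone receptor (Homo sapiens); a lower number here means a stronger inhibitor, a higher number a weaker inhibitor; compound 1 `COCCn1c(SCc2cc([N+](=O)[O-])ccc2OC)nc2cc(NC(=O)NC(C)(C)C)ccc21` gives 57 nM there, while compound 2 gives 270 nM, a gap beyond the usual scatter. Compound 3 `CCCn1c(SCc2cc([N+](=O)[O-])ccc2OC)nc2cc(NC(=O)NC(C)(C)C)cc(C(=O)NCc3cccnc3)c21` has not been measured in this assay. It differs from compound 2 in one place: ((pyridin-3-yl)methyl)amino in place of dimethylamino on a carbonyl carbon. Within the data shown here, no measured pair shows this change, so its size is unknown; a step of modest size is expected, in either direction, with the step from compound 2 to compound 3 estimated at a 1.8-fold lower number from compound 2 to compound 3 (0.26 log units; within the scatter). For compound 3 the expected value in this assay is 150 nM, within a range of 40 nM to 600 nM.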

Compound 3, half-maximal inhibitory concentration: 69 nM
Compound 3: the middle estimate sits 2.2-fold (0.34 log units) above what was measured; the measured number falls inside the stated range.
By their numbers in this assay, from the lowest: compounds 1 and 3 (each within the scatter of the next); then compound 2.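

In this assay, among these compounds, this position responds to the group on the carbonyl carbon: ((pyridin-3-yl)methyl)amino in place of dimethylamino gives a 3.9-fold lower number from compound 2 to compound 3 (0.59 log units; beyond the scatter) as the first reading of this change. The entering group brings both a six-membered aromatic ring with 1 hetero atom and 1 hydrogen-bond donor, and this single pair does not separate the two. Nothing at hand accounts for the step.

Open, from the compounds shown here alone, is whether methylamino or benzylamino on the same carbonyl carbon would keep this step.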